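Propyl to butyl on two cores: a small step expected

The source may hold more compounds than are shown below. What is called first, only, known or untested is meant among the compounds shown, and "the series" means these compounds.

Compound 1 `CCCN(C)/N=N/c1n[nH]cc1C(N)=O` gives 3.7 in a functional assay on L1210 cells (Mus musculus) for antiproliferative activity; a lower number here means a less potent compound, a higher number a more potent compound, by a factor of ten per unit of this negative logarithm. Compound 3 `CCCCN(C)/N=N/c1n[nH]cc1C(N)=O` differs from it by methyl in place of hydrogen on a saturated chain carbon, three bonds along the chain from an amine nitrogen and gives 3.81 in this assay. The step of a number 0.11 log units higher from compound 1 to compound 3 (within the scatter) is accordingly small. Compound 2 `CCCN(C)/N=N/c1ccccc1C(N)=O` carries another core; the difference between the two cores is not broken down here. In this assay compound 2 gives 3.26, the lowest of the three numbers, with compound 1 and compound 3 both beyond the scatter above it. Compound 4 `CCCCN(C)/N=N/c1ccccc1C(N)=O` is not yet measured and differs from compound 2 by methyl in place of hydrogen on a saturated chain carbon, three bonds along the chain from an amine nitrogen, the same change already seen. Because that earlier step was a number 0.11 log units higher from compound 1 to compound 3 (within the scatter), the expected step in this assay is similarly small, a number 0.11 log units higher from compound 2 to compound 4 (within the scatter). Compound 4 is thus estimated at 3.37, between 3 and 3.75.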

Compound 4, logarithm of the reciprocal of the active concentration, log(1/C): 3.1
For compound 4 the middle estimate is 0.27 log units above the measured one; low and high end bracket the measured number.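

The propyl to butyl change, made on the core of compound 2, comes out as a number 0.16 log units lower from compound 2 to compound 4 (within the scatter) in this assay. Set beside the earlier step, it does not differ from it by more than repeated measurements allow: the same change on two cores in this assay, a number 0.11 log units higher (within the scatter) from compound 1 to compound 3 and a number 0.16 log units lower (within the scatter) from compound 2 to compound 4, 0.27 log units apart, within the scatter of two such steps

So this change stays small on both cores, but a single pair on each core cannot fix a common direction for the step, nor show that it would stay small on any further core.

As far as these compounds go, what remains open is how a longer chain, or an amine at the end of the chain, would read in this assay on either core. From the compounds shown here alone, a carboxylic acid in place of the amide is equally open.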